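From 3,5-dichlorophenyl to naphthalen-1-yl on compound 3

The compounds below may be only part of what the source reports. "The series", "measured", "known", "first", "only" and "open" are said of these compounds alone.

In a functional assay on BaF3 cells (Mus musculus) for inhibition, read by MTT assay, with a stated time of 3 days (on this read-out lower numbers stand for stronger inhibition of growth and higher numbers for weaker inhibition of growth), compound 1 (`O=C(Nc1ccc(Br)cc1)Nc1ccc(Nc2ncnc3c2OCCN3)cc1`) gives 10000 nM and compound 3 (`O=C(Nc1ccc(Nc2ncnc3c2OCCN3)cc1)Nc1cc(Cl)cc(Cl)c1`) stands level with it at 10000 nM on the digits shown. Compound 2 (`Cc1ccc(F)c(NC(=O)Nc2ccc(Nc3ncnc4c3OCCN4)cc2)c1`) reads > 10000 nM and that is a limit of the assay, not a number. Its two steps have no readable size (a number no lower from compound 1 to compound 2 (the limit leaves the size open)) and (a number no higher from compound 2 to compound 3 (the limit leaves the size open)). Compound 4 (`O=C(Nc1ccc(Nc2ncnc3c2OCCN3)cc1)Nc1cccc2ccccc12`) carries naphthalen-1-yl in place of 3,5-dichlorophenyl on an amide-type nitrogen. Among the compounds with values here, only one measured step has a readable size, and it stays within the scatter (no change at the digits printed from compound 1 to compound 3 (within the scatter)). On that basis no step beyond the scatter is expected in this assay (no change at the digits printed from compound 3 to compound 4 (within the scatter)). For compound 4 the estimated value is 10000 nM with an expected range of 3000 nM to 20000 nM here.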

Compound 4, concentration for 50% growth inhibition: > 10000 nM
Compound 4: no number, only a limit; the forecaster's own chance of this, stated with the estimate: 45%; the middle value lies on the limit itself.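

In this assay compound 4 gives > 10000 nM, which is a limit of the assay and not a number. The result is a number no lower from compound 3 to compound 4 (the limit leaves the size open), and likewise a number no lower from compound 1 to compound 4 (the limit leaves the size open). None of the steps to compound 4 can be read, so naphthalen-1-yl in place of 3,5-dichlorophenyl on the amide-type nitrogen adds no measured step size. What is new is that a group with 2 six-membered aromatic rings joins compound 2 at the limit, with no number below it: the limit of > 10000 nM in this assay, at which 2 of the 4 values shown sit.

On these data alone, whether any group here gives a clearly lower number stays open. A phenyl carrying a dimethylamino group or a carboxylic acid would test this in this assay.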